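The source may report more compounds than this note shows. Statements on the series, on what has been measured and on what is new or still open speak of the compounds shown alone.

Compound 1 `COc1ccc2nc(C)cc(OCC(=O)Nc3ccccc3)c2c1` gives 39800 nM in a toxicity assay on HepG2 cells (Homo sapiens) for inhibition, read by CellTiter-Glo, with a stated time of 48 h; a higher number here means a weaker inhibitor, a lower number a stronger inhibitor. Compound 2 `COc1ccc(NC(=O)COc2cc(C)nc3ccc(OC)cc23)cc1` reaches only the limit of > 100000 nM in this assay. Compound 3 `COc1ccc2nc(C)cc(OCC(=O)Nc3ccc(Br)c(C)c3)c2c1` gives 15900 nM in this assay, which is the lowest of the two numbers measured, with compound 1 the nearest of them. The step from compound 1 to compound 3 brought a 2.5-fold lower number from compound 1 to compound 3 (0.40 log units; beyond the scatter), and the step from compound 2 to compound 3 brought an at least 6.2-fold lower number from compound 2 to compound 3 (0.79 log units; beyond the scatter), while the step from compound 1 to compound 2 brought an at least 2.5-fold higher number from compound 1 to compound 2 (0.40 log units; beyond the scatter). Compound 4 `COc1ccc2nc(C)cc(OCC(=O)Nc3ccc(Cl)cc3Cl)c2c1` has not yet been measured; it differs from compound 3 by 2,4-dichlorophenyl in place of 4-bromo-3-methylphenyl on an amide-type nitrogen. Both measured steps that end at compound 3 end at a ring carrying a halogen and gave lower numbers, whereas compound 2, whose ring carries a methoxy group, sits at the limit of > 100000 nM in this assay, at which 1 of the 3 values shown sits. Compound 4 keeps a halogen-bearing ring on the amide nitrogen, so the step from compound 3 to compound 4 is expected to be a 1.1-fold lower number from compound 3 to compound 4 (0.03 log units; within the scatter), within the scatter. Compound 4 is therefore estimated at 15000 nM, expected to fall between 6000 nM and 40000 nM.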

Compound 4, half-maximal inhibitory concentration: > 100000 nM
Compound 4 ended at the assay's limit; the forecaster's own chance of this, stated with the estimate: 5%; middle value at least 6.6-fold (0.82 log units) from the limit.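

The halogen on the ring at the amide nitrogen does not by itself go with a lower number: 2,4-dichlorophenyl in place of 4-bromo-3-methylphenyl gives an at least 6.2-fold higher number from compound 3 to compound 4 (0.79 log units; beyond the scatter). The same group in place of phenyl gives an at least 2.5-fold higher number from compound 1 to compound 4 (0.40 log units; beyond the scatter), so compound 3 and compound 4, both with halogen-bearing rings, now lie on opposite sides of compound 1. Compound 2 and compound 4 both stand at a limit rather than at a number, and the step between them cannot be read: the limit of > 100000 nM in this assay, at which 2 of the 4 values shown sit.

On these data alone, the step from compound 3 to compound 4 alters the halogen and the other ring substituents together, so the part played by each stays open. Also open, as far as these compounds go, is what a ring with a single chlorine, a single bromine, an amine or a carboxylic acid would give at this position.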